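Methoxy removal on two hydrazone cores

The source may report more compounds than this note shows. Statements on the series, on what has been measured and on what is new or still open speak of the compounds shown alone.

In a functional assay on cells (Mus musculus) for cytotoxicity, read by MTT assay, with a stated time of 24 h, tested at 1 uM (a lower number here means a weaker effect, a higher number a stronger effect of the compound at the concentration tested), compound 1 `COc1cc(/C=N/N(C)c2nc3ccccc3s2)cc(OC)c1O` gives 107% and compound 3 `COc1cc(/C=N/N(C)c2nc3ccccc3s2)ccc1O` gives 96%. The change between them, (hydrogen in place of methoxy on an aromatic carbon), made a step of a number 11 percentage points lower from compound 1 to compound 3 (beyond the scatter). Compound 2 `COc1cc(/C=N/NC(=O)c2ccncc2)cc(O)c1O` is built on a different core; the difference between the two cores is not broken down here. In this assay compound 2 gives 41%, the lowest number among the three measured compounds. Compound 4 `O=C(N/N=C/c1ccc(O)c(O)c1)c1ccncc1` has not yet been measured in this assay. It differs from compound 2 by hydrogen in place of methoxy on an aromatic carbon, the same kind of change as from compound 1 to compound 3, though the surroundings are not the same: in compound 1 the leaving methoxy is meta to a methoxy group, in compound 2 it is meta to a hydroxy group. The earlier step was made on a core giving high numbers, while compound 2 starts from a far lower number. The step from compound 2 to compound 4 is expected to be a number 9 percentage points lower from compound 2 to compound 4 (within the scatter), a modest lowering beside the earlier one, resting on the step of a number 11 percentage points lower from compound 1 to compound 3 (beyond the scatter). Compound 4 is estimated at 32%, with a range of 15% to 55%.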

Compound 4, a percentage reported as activity, at one concentration (the size of the read-out at that concentration, not a potency): 84%
Compound 4: the middle estimate sits 52 percentage points below what was measured; the whole stated range lies below it.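

In this assay, hydrogen in place of methoxy on an aromatic carbon gives a number 43 percentage points higher from compound 2 to compound 4 (beyond the scatter), so the change does not carry over between these two cores in either size or direction: the same change on two cores in this assay, a number 11 percentage points lower (beyond the scatter) from compound 1 to compound 3 and a number 43 percentage points higher (beyond the scatter) from compound 2 to compound 4, 54 percentage points apart, beyond the scatter of two such steps

The result shows that a step read on one core in this series cannot be transferred to the other as it stands. It does not show whether the core itself or the other groups on the ring set the difference, since the methoxy leaving compound 2 is ortho to a hydroxy group and meta to a hydroxy group, and the surroundings of the change are not the same on the two cores.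

The compounds shown leave open how either core responds when the methoxy is replaced by something other than hydrogen, such as an amine, a chlorine or a longer chain like ethoxy. With one step per core and a read-out at a single concentration, they also leave open whether the stronger or weaker effect seen at that concentration would hold at any other.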